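This account rests on a few compounds, and the source may have more. Where it says the series, first, only, none or still open, it means among the compounds named here.

Compound 1, `CC(C)N(Cc1cccc(OCCCCCC(=O)O)c1)C(=O)c1ccc(-c2ccoc2)cc1`: in an ADME assay on HepG2 cells (Homo sapiens) for cytotoxicity, read by CellTiter-Glo and resazurin assay, with a stated time of 72 h (a higher number here means that more compound is needed for the effect, a lower number that less compound is needed), compound 1 gives only the assay limit > 26000 nM, not a number.
Compound 2, `CC(C)N(Cc1cccc(OCCCCCC(=O)O)c1)C(=O)c1ccc(-c2ccc3[nH]ccc3c2)cc1`: in this assay compound 2 likewise stops at the limit > 26000 nM.
Compound 3, `CCOc1cccc(-c2ccc(C(=O)N(Cc3cccc(OCCCCCC(=O)O)c3)C(C)C)cc2)c1`: in this assay compound 3 reaches only the limit > 20800 nM.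

Compound 3 therefore stands at a limit, like the other two, at the limit of > 20800 nM in this assay, at which 1 of the 3 values shown sits, beside (the limit of > 26000 nM in this assay, at which 2 of the 3 values shown sit). The steps onto it, a step that the two limits leave unreadable from compound 1 to compound 3 and a step that the two limits leave unreadable from compound 2 to compound 3, cannot be sized. Compound 4, `CC(C)N(Cc1cccc(OCCCCCC(=O)O)c1)C(=O)c1ccc(-c2cccc(OC(F)(F)F)c2)cc1`, differs from compound 3 by trifluoromethyl in place of ethyl on an oxygen on an aromatic ring. With no readable step behind it, the expectation for compound 4 is no step beyond the scatter, a step that the limit leaves unreadable from compound 3 to compound 4, and most likely another limit. Compound 4 is thus estimated at 30000 nM, between 15000 nM and 80000 nM.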

Compound 4, half-maximal effective concentration: > 26000 nM
Compound 4 ended at the assay's limit; the forecaster's own chance of this, stated with the estimate: 80%; the middle value lies beyond the limit too.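

In this assay compound 4 gives only the limit > 26000 nM, and its steps from compound 1, compound 2 and compound 3 cannot be read. The compounds shown leave open whether these aromatic groups differ in cytotoxicity at all.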